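The source may hold more compounds than are shown below. What is called first, only, known or untested is meant among the compounds shown, and "the series" means these compounds.

In a functional assay on COLO 205 cells (Homo sapiens) for cytotoxicity, read by MTT assay, with a stated time of 72 h (on this read-out lower numbers stand for stronger inhibition and higher numbers for weaker inhibition), compound 1 `COc1ccc(C(=O)c2cc(OC)c(OC)c(OC)c2)cc1N` gives 200 nM.
Compound 2 `COc1ccc(/C=C/C(=O)Nc2cc(C(=O)c3cc(OC)c(OC)c(OC)c3)cc(OC)c2OC)cc1OC` gives 5700 nM.

Of these two numbers, compound 2 holds the higher one, and its gap to compound 1 is wider than the scatter of repeated measurements. Compound 3 `COc1cc(C(=O)c2cc(OC)c(OC)c(OC)c2)cc(NC(=O)/C=C/c2cc(F)c(F)c(F)c2)c1OC` has not been measured. It differs from compound 2 in one place: 3,4,5-trifluorophenyl in place of 3,4-dimethoxyphenyl on a double-bonded chain carbon bound to a double-bonded chain carbon. Within the data shown here, no pair of measured compounds shows what such a swap does, so the expected step, a 1.1-fold lower number from compound 2 to compound 3 (0.06 log units; within the scatter), is modest and may not reach beyond the scatter. Compound 3 is therefore estimated at 5000 nM, with a range from 1500 nM to 16000 nM.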

Compound 3, half-maximal inhibitory concentration: 4300 nM
For compound 3 the middle estimate is 1.2-fold (0.07 log units) above the measured one; low and high end bracket the measured number.
By their numbers in this assay, from the lowest: compound 1; then compounds 3 and 2 (each within the scatter of the next).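

Replacing 3,4-dimethoxyphenyl with 3,4,5-trifluorophenyl on a double-bonded chain carbon bound to a double-bonded chain carbon gives a 1.3-fold lower number from compound 2 to compound 3 (0.12 log units; within the scatter) in this assay, so the two compounds cannot be told apart. At this position, then, the hydrogen-bond acceptors counted on 3,4-dimethoxyphenyl can go without a visible mark on the number. Nothing at hand explains why the two groups read alike.

Only these two groups can be compared at this position. From the compounds shown here alone, whether an unsubstituted phenyl, a pyridine ring or an amine there would read differently remains open.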